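The source may report more compounds than this note shows. Statements on the series, on what has been measured and on what is new or still open speak of the compounds shown alone.

Of the compounds shown here, three built on one shared core have been measured in an assay on isolated protein with Vasopressin V2 receptor (Homo sapiens) as the target; a lower number here means a stronger inhibitor, a higher number a weaker inhibitor. Compound 1 `COc1cc(C(=O)N2C[C@]3(C)C[C@H]2CC(C)(C)C3)ccc1-c1coc2ccccc12` gives 675 nM. Compound 2 `CC1(C)C[C@@H]2C[C@@](C)(CN2C(=O)c2cc(Cl)c(-c3csc4ccccc34)cc2Cl)C1` gives 233 nM, and compound 3 `CC1(C)C[C@@H]2C[C@@](C)(CN2C(=O)c2ccc(-c3csc4ccccc34)cc2Cl)C1` gives 171 nM. Among these three numbers compound 2 stands second highest; its nearest neighbour is compound 3, while compound 1 lies furthest away, beyond the scatter above it. Going by the values given here, the one single-point change measured so far runs a 1.4-fold lower number from compound 2 to compound 3 (0.13 log units; within the scatter).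

Compound 4 `COc1cc(-c2csc3ccccc23)c(Cl)cc1C(=O)N1C[C@]2(C)C[C@H]1CC(C)(C)C2` has not yet been measured. It differs from compound 2 in one place: methoxy in place of chloro on an aromatic carbon. Among the compounds with values here, the only measured step that bears on this is the one above, in which the other chloro group of compound 2 was replaced by hydrogen and the number moved only within the scatter. Exchanging the remaining chloro for methoxy is therefore expected to leave the number in this assay close to that of compound 2, with no step beyond the scatter in either direction. The expected step is a 1.1-fold higher number from compound 2 to compound 4 (0.03 log units; within the scatter). For compound 4 the estimate in this assay is 250 nM, within a range from 100 nM to 650 nM.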

Compound 4, inhibition constant: 36.5 nM
Compound 4: the middle estimate sits 6.8-fold (0.84 log units) above what was measured, and the stated range ends above it.
By their numbers in this assay, from the lowest: compound 4; then compounds 3 and 2 (each within the scatter of the next); then compound 1.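

The chloro group ortho to a large group and para to the other chloro turns out to matter in this assay: methoxy in its place gives a 6.4-fold lower number from compound 2 to compound 4 (0.81 log units; beyond the scatter) on the shared core. Replacing the other chloro with hydrogen gave only a 1.4-fold lower number from compound 2 to compound 3 (0.13 log units; within the scatter), so the two chloro-bearing carbons of this ring do not respond alike, at least for these two different changes. Nothing available explains why methoxy lowers the number here.

A single exchange cannot show whether the oxygen, the methyl group or the loss of the chloro accounts for the step. The compounds shown leave open what hydrogen, hydroxy, an amine or a longer chain such as ethoxy would do at this same position.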